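This account rests on a few compounds, and the source may have more. Where it says the series, first, only, none or still open, it means among the compounds named here.

Of the compounds shown here, three sharing one core have been measured in a functional assay, read by spectrophotometry, with a stated time of 2 h, tested at 3 mg/mL; on this read-out lower numbers stand for a weaker effect and higher numbers for a stronger effect at the one concentration tested. Compound 1 `CC(C)[C@@H]1CC[C@@H](C)C[C@@]12N(C)C(=O)[C@@H]1[C@H]3C(=O)N(C)C(=O)[C@H]3ON12` gives 67.5%. Compound 2 `CC(C)[C@@H]1CC[C@@H](C)C[C@@]12N(C)C(=O)[C@@H]1[C@H]3C(=O)N(c4ccccc4)C(=O)[C@H]3ON12` gives 58.9%, and compound 3 `COc1ccc(N2C(=O)[C@H]3[C@H](ON4[C@@H]3C(=O)N(C)[C@@]43C[C@H](C)CC[C@H]3C(C)C)C2=O)cc1` gives 67.7%. On the numbers as read, compound 2 has the smallest, yet compound 1, its nearest neighbour, and compound 3, its furthest, both lie within the scatter of it, so the three cannot be told apart: the step of a number 8.6 percentage points lower from compound 1 to compound 2 (within the scatter), the step of a number 8.8 percentage points higher from compound 2 to compound 3 (within the scatter) and the step of a number 0.2 percentage points higher from compound 1 to compound 3 (within the scatter) were all within the scatter.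

Compound 4 `CC(C)[C@@H]1CC[C@@H](C)C[C@@]12N(C)C(=O)[C@@H]1[C@H]3C(=O)N(c4ccc5ccccc5c4)C(=O)[C@H]3ON12` has not yet been measured. It differs from compound 2 in one place: naphthalen-2-yl in place of phenyl on an amide-type nitrogen in a ring. Going by the values given here, the steps that bear on this change are those that also swap or extend the group on the same ring nitrogen, namely a number 8.6 percentage points lower from compound 1 to compound 2 (within the scatter), a number 0.2 percentage points higher from compound 1 to compound 3 (within the scatter) and a number 8.8 percentage points higher from compound 2 to compound 3 (within the scatter), none of which left the scatter. Because a number 8.6 percentage points lower from compound 1 to compound 2 (within the scatter) and a number 8.8 percentage points higher from compound 2 to compound 3 (within the scatter) both stayed within the scatter, a larger aromatic group on compound 4 is expected to give no step beyond the scatter in either direction. For compound 4 the expected value in this assay is 60%, within a range from 45% to 75%. This amounts to an expected step of a number 1.1 percentage points higher from compound 2 to compound 4 (within the scatter).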

Compound 4, a percentage reported as activity, at one concentration (the size of the read-out at that concentration, not a potency): 57.4%
For compound 4 the middle estimate is 2.6 percentage points above the measured one, within the range that was stated.
By their numbers in this assay, from the lowest: compounds 4, 2, 1 and 3 (each within the scatter of the next, the first and the last beyond it).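

In this assay the second aromatic ring of naphthalen-2-yl, in place of phenyl on the amide-type ring nitrogen, gave a number 1.5 percentage points lower from compound 2 to compound 4 (within the scatter) and so cannot be told apart from phenyl at this position. Going by these compounds alone, the same group gives the first steps to pass the scatter, namely a number 10.3 percentage points lower from compound 3 to compound 4 (beyond the scatter) and a number 10.1 percentage points lower from compound 1 to compound 4 (beyond the scatter) and both modest, which shows that the group on this nitrogen can shift the read-out, although compound 2 stays within the scatter of compounds 1, 3 and 4. No evidence is available that would explain these numbers.

As far as these compounds go, the groups on this nitrogen so far are methyl, phenyl, 4-methoxyphenyl and naphthalen-2-yl, so how an amine, a carboxylic acid or a longer alkyl chain would read there remains open. From the compounds shown here alone, whether naphthalen-1-yl would match naphthalen-2-yl is also open.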